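Cytotoxicity in the diaryl-pyrimidine series: aryl swap at the biaryl position

A few compounds are considered here, and "the series" means these few. Any claim that something is new, unique, unknown or untested is made for them only; others in the source may bear on it.

Of the compounds shown here, three of a shared core have been tested in an ADME assay on MT4 cells (Homo sapiens) for cytotoxicity, read by MTT assay, with a stated time of 4 days; a lower number here means that less compound is tolerated, a higher number that more compound is tolerated. Compound 1 `COc1ccccc1-c1cc(C)c(Nc2ccnc(Nc3ccc(C#N)cc3)n2)c(C)c1` gives 940 nM. Compound 2 `Cc1cc(-c2ccc(Cl)cc2)cc(C)c1Nc1ccnc(Nc2ccc(C#N)cc2)n1` gives 4190 nM, and compound 3 `Cc1cc(-c2ccccc2C(F)(F)F)cc(C)c1Nc1ccnc(Nc2ccc(C#N)cc2)n1` gives 4210 nM. Compound 3 stands highest of the three numbers; its step from compound 2 is a 1.0-fold higher number from compound 2 to compound 3 (0.00 log units; within the scatter), within the scatter, while against compound 1 the step is a 4.5-fold higher number from compound 1 to compound 3 (0.65 log units; beyond the scatter), beyond the scatter. The change from compound 1 to compound 2, a 4.5-fold higher number from compound 1 to compound 2 (0.65 log units; beyond the scatter), is of the same size.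

Compound 4 `Cc1cc(C)cc(-c2cc(C)c(Nc3ccnc(Nc4ccc(C#N)cc4)n3)c(C)c2)c1` carries 3,5-dimethylphenyl in place of 2-(trifluoromethyl)phenyl on an aromatic carbon. Going by the values given here, the step that bears most directly on it is the exchange of one aryl group for another at this position, a 1.0-fold higher number from compound 2 to compound 3 (0.00 log units; within the scatter), which lay within the scatter; the only steps beyond the scatter both start from the 2-methoxyphenyl of compound 1, which is not involved here. Hence no step beyond the scatter is expected in this assay for compound 4, an estimated change of a 1.2-fold lower number from compound 3 to compound 4 (0.08 log units; within the scatter). Compound 4 is estimated at 3500 nM, within the range 1200 nM to 10000 nM.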

Compound 4, half-maximal cytotoxic concentration: 4140 nM
Compound 4: middle estimate off by 1.2-fold (0.07 log units), on the low side; low and high end bracket the measured number.
By their numbers in this assay, from the lowest: compound 1; then compounds 4, 2 and 3 (each within the scatter of the next).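

In this assay, the 3,5-dimethylphenyl group, which carries no halogen, sits level with both halogen-bearing aryl groups: a 1.0-fold lower number from compound 3 to compound 4 (0.01 log units; within the scatter), and a 1.0-fold lower number from compound 2 to compound 4 (0.01 log units; within the scatter). Among the aryl groups shown, the 2-methoxyphenyl of compound 1 alone stands apart, a 4.4-fold higher number from compound 1 to compound 4 (0.64 log units; beyond the scatter), so the separation now holds against three different aryl groups and does not depend on a halogen being present. Nothing measured here accounts for this separation.

From the compounds shown here alone, whether the methoxy group itself sets compound 1 apart remains open, as does the part played by where it sits on the aryl ring. Also open, going by these compounds, is how a hydroxy group, an amine or a carboxylic acid on this aryl group would read in this assay.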